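From 2-vinylphenyl to thiophen-2-yl: an expectation among limits

The compounds below may be only part of what the source reports. "The series", "measured", "known", "first", "only" and "open" are said of these compounds alone.

Of the compounds shown here, three sharing one core have been tested in a functional assay on HUVEC cells (Homo sapiens) (a lower number here means that less compound is needed, a higher number that more compound is needed for the effect), and none has given an exact number. Compound 1 (`COC1=C(C)C(=O)/C(=C(O)/C=C/c2cccc(OC)c2)C(=O)C1(C)C`) gives < 4 ug/mL as a limit of the assay. Compound 2 (`COC1=C(C)C(=O)/C(=C(O)/C=C/c2ccc(O)cc2)C(=O)C1(C)C`) gives < 4 ug/mL as a limit as well. Compound 3 (`C=Cc1ccccc1/C=C/C(O)=C1/C(=O)C(C)=C(OC)C(C)(C)C1=O`) gives < 1.1 ug/mL as a limit too, so its standing is known only as a limit. Compound 4 (`COC1=C(C)C(=O)/C(=C(O)/C=C/c2cccs2)C(=O)C1(C)C`) carries thiophen-2-yl in place of the 2-vinylphenyl of compound 3 (thiophen-2-yl in place of 2-vinylphenyl on a double-bonded chain carbon bound to a double-bonded chain carbon). The record at this place on the chain holds a step that the two limits leave unreadable from compound 1 to compound 2 and a step that the two limits leave unreadable from compound 2 to compound 3 as two of its steps. Since a step that the two limits leave unreadable from compound 1 to compound 3 gives no direction either, no step beyond the usual scatter is expected in this assay for this change. The expected step is an at least 1.0-fold higher number from compound 3 to compound 4 (0.03 log units; that floor lies within the scatter) as an estimate only. For compound 4 the estimated value is 1.2 ug/mL with an expected range from 0.4 ug/mL to 4 ug/mL around it.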

Compound 4, concentration for half-maximal effect: < 4 ug/mL
Compound 4: a limit, no number; the forecaster's own chance of this, stated with the estimate: 60%; the middle value lies beyond the limit too.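

Among the compounds shown here, compound 4 gives only a limit, as do compound 1, compound 2 and compound 3, so no step to compound 4 can be read. Going by these compounds, whether thiophen-2-yl, 2-vinylphenyl, 4-hydroxyphenyl and 3-methoxyphenyl differ at all in the concentration needed remains open.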